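The source may hold more compounds than are shown below. What is called first, only, known or untested is meant among the compounds shown, and "the series" means these compounds.

Measured compounds:
Compound 1 `CC(=O)Nc1cccc(-c2ccc(C(=O)N(Cc3cccc(OCCCCCC(=O)O)c3)C(C)C)cc2)c1` gives > 26000 nM in an ADME assay on Raji cells (Homo sapiens) for cytotoxicity, read by CellTiter-Glo and resazurin assay, with a stated time of 72 h; on this read-out higher numbers stand for an effect only at larger amounts of compound and lower numbers for an effect already at smaller amounts; this is a limit of the assay.
Compound 2 `CC(C)N(Cc1cccc(OCCCCCC(=O)O)c1)C(=O)c1ccc(-c2cccc(OCc3ccccc3)c2)cc1` gives > 26000 nM in this assay; this too is a limit of the assay.

Among the compounds with values here, compound 2 therefore stands at the limit of this assay, and so does the one other value shown, as the limit of > 26000 nM in this assay, at which 2 of the 2 values shown sit, states. Within the data shown here, the one measured step, a step that the two limits leave unreadable from compound 1 to compound 2, runs between two limits and so tells nothing about how large a change that swap brought.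

Compound 3 `Cc1nnc(-c2cccc(-c3ccc(C(=O)N(Cc4cccc(OCCCCCC(=O)O)c4)C(C)C)cc3)c2)o1` differs from compound 2 in one place: 5-methyl-1,3,4-oxadiazol-2-yl in place of benzyloxy on an aromatic carbon. Among the measured compounds shown here, no measured step bears on this change, since the only step available is unreadable. What remains is the position of compound 2 itself, sitting at the limit. On that basis compound 3 is expected to stay near the same limit, with an expected step of a number no higher from compound 2 to compound 3 (the limit leaves the size open) that means no shift beyond the scatter. The estimate for compound 3 is 26000 nM, ranging from 13000 nM to 52000 nM.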

Compound 3, half-maximal effective concentration: > 26000 nM
Compound 3 gave a limit, no number (the forecaster's own chance of this, stated with the estimate: 80%); the middle value sits exactly at the limit.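

The steps linking compound 1, compound 2 and compound 3 cannot be read, since all three results are the same limit and not numbers: the limit of > 26000 nM in this assay, at which 3 of the 3 values shown sit.

The compounds shown leave open whether the acetamido, benzyloxy and 5-methyl-1,3,4-oxadiazol-2-yl groups differ at all in this assay.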